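The source may hold more compounds than are shown below. What is called first, only, known or untested is meant among the compounds shown, and "the series" means these compounds.

Compound 1 `COc1cc(Nc2nc(N[C@H]3CC[C@H](N)CC3)nc3c2ncn3CCC(C)C)cc(OC)c1` gives 4500 nM in a functional assay on MCF7 cells (Homo sapiens) for inhibition, read by fluorescence, with a stated time of 72 h; a higher number here means a weaker inhibitor of growth, a lower number a stronger inhibitor of growth.
Compound 2 `CCCCCCn1cnc2c(Nc3cc(OC)cc(OC)c3)nc(N[C@H]3CC[C@H](N)CC3)nc21` gives 3500 nM in this assay.
Compound 3 `CCCCCCn1cnc2c(Nc3cccc(Cl)c3)nc(N[C@H]3CC[C@H](N)CC3)nc21` gives 2700 nM in this assay.

Compound 4 `CC(C)CCn1cnc2c(Nc3cccc(Cl)c3)nc(N[C@H]3CC[C@H](N)CC3)nc21` has not yet been measured. It differs from compound 3 by isopropyl in place of butyl on a saturated chain carbon, two bonds along the chain from an aromatic nitrogen. The same change has already been made once, from compound 2 to compound 1, where the difference is isopropyl in place of butyl on a saturated chain carbon, two bonds along the chain from an aromatic nitrogen and the step was a 1.3-fold higher number from compound 2 to compound 1 (0.11 log units; within the scatter). The two starting points, compound 2 and compound 3, differ by 3-chlorophenyl in place of 3,5-dimethoxyphenyl on a nitrogen on an aromatic ring, a step of a 1.3-fold lower number from compound 2 to compound 3 (0.11 log units; within the scatter). Among the compounds with values here, the place of the change is the same in both pairs, so the earlier step is the only guide. Because the earlier step was a 1.3-fold higher number from compound 2 to compound 1 (0.11 log units; within the scatter), the step to compound 4 is expected to be a 1.3-fold higher number from compound 3 to compound 4 (0.11 log units; within the scatter). Compound 4 is therefore estimated to give about 3500 nM in this assay, with a likely range from 1800 nM to 7000 nM.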

Compound 4, concentration for 50% growth inhibition: 2100 nM
Estimate against measurement, compound 4: 1.7-fold (0.22 log units) above; the range from low to high includes it.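

Putting isopropyl in place of butyl gives a 1.3-fold lower number from compound 3 to compound 4 (0.11 log units; within the scatter), and this step agrees with the one seen earlier on the other core: the same change on two cores in this assay, a 1.3-fold higher number (0.11 log units; within the scatter) from compound 2 to compound 1 and a 1.3-fold lower number (0.11 log units; within the scatter) from compound 3 to compound 4, 1.7-fold (0.22 log units) apart, within the scatter of two such steps

Putting 3-chlorophenyl in place of 3,5-dimethoxyphenyl gives a 2.1-fold lower number from compound 1 to compound 4 (0.33 log units; beyond the scatter), and this change also carries from one core to the other: the same change on two cores in this assay, a 1.3-fold lower number (0.11 log units; within the scatter) from compound 2 to compound 3 and a 2.1-fold lower number (0.33 log units; beyond the scatter) from compound 1 to compound 4, 1.7-fold (0.22 log units) apart, within the scatter of two such steps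

So in this assay neither change shows any dependence on the core, but each has been seen on only two cores and all the steps are small, so this does not show that either would carry over to other cores or to larger changes.

Still open, as far as these compounds go, is how a chain ending in an amine or a carboxylic acid would compare with hexyl or isopentyl on the shared core. Also open, from the compounds shown here alone, is how a phenyl bearing a nitrile would compare with 3-chlorophenyl.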